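The source may hold more compounds than are shown below. What is called first, only, known or untested is meant among the compounds shown, and "the series" means these compounds.

Measured compounds:
- compound 1 `COc1ccc(OCC2=NCCO2)cc1` gives 15%
- compound 2 `Brc1ccc(OCC2=NCCO2)cc1` gives 15%

Both compounds share the same core and differ only in one group on an aromatic carbon. In a toxicity assay on the whole organism with Rattus norvegicus as the target, at a dose of 400 mg/kg by the oral route (a lower number here means a weaker effect, a higher number a stronger effect of the compound at the dose given), compound 1 gives 15%, and compound 2 gives 15%. Within the data shown here, the one measured step, no change at the digits printed from compound 1 to compound 2 (within the scatter), shows that swapping one substituent on that aromatic carbon for another left the read-out unchanged. Compound 2 therefore stands level with compound 1 within the scatter, and neither compound can be called stronger or weaker than the other.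

Compound 3 `O=[N+]([O-])c1ccc(OCC2=NCCO2)cc1` is the next compound in this series. It differs from compound 2 in one place: nitro in place of bromo on an aromatic carbon.

Among the measured compounds shown here, the only measured step that bears on this change is the exchange of one group on the same aromatic carbon, which gave no change in this assay. For the measured compounds named here, no measured compound carries a nitro group, so there is no direct guide to it. On the evidence at hand, the step from compound 2 to compound 3 is expected to stay within the scatter, no change at the digits printed from compound 2 to compound 3 (within the scatter). Compound 3 is therefore estimated to give 15% in this assay, with a range from 5% to 32%.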

Compound 3, a percentage reported as activity, at one dose (the size of the read-out at that dose, not a potency): 20%
Compound 3: middle estimate off by 5 percentage points, on the low side; measured number inside the range.
By their numbers in this assay, from the lowest: compounds 1, 2 and 3 (each within the scatter of the next).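

In this assay, nitro is the third group seen on this aromatic carbon, and it too stays within the scatter of the others, with a number 5 percentage points higher from compound 2 to compound 3 (within the scatter) and a number 5 percentage points higher from compound 1 to compound 3 (within the scatter). Methoxy, bromo and nitro therefore cannot be told apart at this position at this dose, even though the step from bromo to nitro replaces a single bromine atom with 3 heavy atoms, a double bond outside the aromatic ring and 2 hydrogen-bond acceptors. Nothing measured here accounts for this result.

As far as these compounds go, it remains open whether a group of another kind on this carbon, such as an amine, a carboxylic acid or a longer alkoxy chain, would give a number beyond the scatter of these three compounds. The compounds shown also leave open what happens when a group sits on a different carbon of the aromatic ring, or when the shared core itself is altered, since all three compounds vary in this one place only.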